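From methyl to (tert-butoxycarbonyl)amino on an aromatic carbon

This account rests on a few compounds, and the source may have more. Where it says the series, first, only, none or still open, it means among the compounds named here.

Measured values in a functional assay on HCT-116 cells (Homo sapiens) for antiproliferative activity, read by MTT assay, with a stated time of 72 h; a higher number here means a weaker inhibitor, a lower number a stronger inhibitor
compound 1 `O=C(CCc1cccc2c1B(O)OC2)Nc1ccc(F)cc1` gives 650 nM
compound 2 `O=C(CCc1cccc2c1B(O)OC2)Nc1ccc(I)cc1` gives 50000 nM
compound 3 `Cc1ccc(NC(=O)CCc2cccc3c2B(O)OC3)cc1` gives 4500 nM

Of the three numbers, compound 3 holds the second highest, lying between the other two. Compound 4 `CC(C)(C)OC(=O)Nc1ccc(NC(=O)CCc2cccc3c2B(O)OC3)cc1` carries (tert-butoxycarbonyl)amino in place of methyl on an aromatic carbon, para to a large group ((tert-butoxycarbonyl)amino in place of methyl on an aromatic carbon). Among the compounds with values here, no measured compound carries this group, so the evidence is indirect. Methyl in place of fluoro gave a 6.9-fold higher number from compound 1 to compound 3 (0.84 log units; beyond the scatter) and iodo in place of fluoro gave a 77-fold higher number from compound 1 to compound 2 (1.89 log units; beyond the scatter) in this series. Methyl in place of iodo gave an 11-fold lower number from compound 2 to compound 3 (1.05 log units; beyond the scatter) and so every exchange among these three groups moved the number beyond the scatter. A change at this carbon is therefore unlikely to pass without effect, although three compounds cannot fix its direction. Going by compound 2 at 50000 nM and its upward step from fluoro, a modest rise is expected in this assay with a fall not ruled out. The estimated step is a 2.7-fold higher number from compound 3 to compound 4 (0.43 log units; beyond the scatter) and its uncertainty is wide. Compound 4 is expected at 12000 nM within an estimated range of 2000 nM to 60000 nM in this measurement.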

Compound 4, half-maximal inhibitory concentration: 24000 nM
The estimate for compound 4 lay 2.0-fold (0.30 log units) below the measured number; the measured number falls inside the stated range.
By their numbers in this assay, from the lowest: compound 1; then compound 3; then compound 4; then compound 2.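

In this assay, the (tert-butoxycarbonyl)amino group shows that this aromatic carbon accepts an entering group of 8 heavy atoms with no ring, and that such a group still gives a measurable number, with a 5.3-fold higher number from compound 3 to compound 4 (0.73 log units; beyond the scatter) as the cost of replacing methyl. The size of the group does not by itself set the order, since this much larger group does not give the highest number: the exchange for iodo gives a 2.1-fold lower number from compound 2 to compound 4 (0.32 log units; beyond the scatter), leaving the iodo of compound 2 as the weakest of the four. Fluoro remains the best of the groups shown, with a 37-fold higher number from compound 1 to compound 4 (1.57 log units; beyond the scatter), so the first group with a hydrogen-bond donor and acceptors at this carbon comes nowhere near compound 1.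

Nothing given here explains this order of fluoro, methyl, (tert-butoxycarbonyl)amino and iodo. From the compounds shown here alone, whether the free amine, a hydroxyl or a chlorine at this carbon would stand nearer to compound 1 or to compound 2 remains open, as does whether the hydrogen-bond donor of the carbamate or the tert-butyl group accounts for the step from compound 3.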